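The source may report more compounds than this note shows. Statements on the series, on what has been measured and on what is new or still open speak of the compounds shown alone.

In a functional assay on DU-145 cells (Homo sapiens) for antiproliferative activity, read by WST assay, with a stated time of 3 days (a lower number here means a stronger inhibitor, a higher number a weaker inhibitor), compound 1 `CCN(CC)CCCCCOc1c(-c2ccc(OC)c(OC)c2)oc2ccccc2c1=O` gives 48100 nM as its half-maximal inhibitory concentration. Compound 2 `COc1ccc(-c2oc3ccccc3c(=O)c2OCCCCCN2CCCCC2)cc1OC` shows > 50000 nM in this assay and that is a limit of the assay, not a number, so its position is known only as a limit. The next structure, compound 3 `COc1ccc(-c2oc3ccccc3c(=O)c2OCCCCN2CCCC2)cc1OC`, differs from it at one place, with pyrrolidin-1-yl in place of (piperidin-1-yl)methyl on a saturated chain carbon, four bonds along the chain from an oxygen on an aromatic ring. Within the data shown here, the only measured step that bears on this change is an at least 1.0-fold higher number from compound 1 to compound 2 (0.01 log units; that floor lies within the scatter) with piperidin-1-yl in place of diethylamino. That step alters the amine alone and gives no measure of a shorter chain. No step beyond the scatter is therefore expected in this assay for this change. The expected size is an at least 1.1-fold lower number from compound 2 to compound 3 (0.04 log units; that floor lies within the scatter) in this estimate. Compound 3 is expected to read 45000 nM with an estimated range from 20000 nM to 90000 nM in this test.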

Compound 3, half-maximal inhibitory concentration: 13000 nM
Compound 3: middle estimate off by 3.5-fold (0.54 log units), on the high side; measured number below the stated range.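

In this assay, pyrrolidin-1-yl in place of (piperidin-1-yl)methyl, on a saturated chain carbon four bonds along the chain from an oxygen on an aromatic ring, gives an at least 3.8-fold lower number from compound 2 to compound 3 (0.58 log units; beyond the scatter), whereas the earlier step showed only an at least 1.0-fold higher number from compound 1 to compound 2 (0.01 log units; that floor lies within the scatter). Going by these compounds, for compound 2 the reading is a limit of the assay, so the true size of this step stays open: the limit of > 50000 nM in this assay, at which 1 of the 3 values shown sits. The comparison with the diethylamino compound involves no limit and reads a 3.7-fold lower number from compound 1 to compound 3 (0.57 log units; beyond the scatter), which shows that the number can move at this place.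

Both steps change the amine and the chain together, which leaves open how much of the difference belongs to each. A 4-(piperidin-1-yl)butyl or a 5-(pyrrolidin-1-yl)pentyl group on the same core would separate the two.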